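A Nitro Group Replaces a Hydrogen on Compound 1

A few compounds are considered here, and "the series" means these few. Any claim that something is new, unique, unknown or untested is made for them only; others in the source may bear on it.

Compound 1, `Nc1scc(-c2ccccc2)c1C(=O)c1ccc(Cl)cc1`, was tested in a functional assay on CHO cells for agonist activity at adenosine receptor A1 (Homo sapiens), read by fluorescence and ERK phosphorylation, with stated times of 30 min and 1.5 h, tested at 3 uM (on this read-out lower numbers stand for a weaker effect and higher numbers for a stronger effect at the one concentration tested), where compound 1 gives 51%. Compound 2, `Nc1scc(-c2ccc(Br)cc2)c1C(=O)c1ccc(Cl)cc1`, gives 45% in this assay, and compound 1 stands alongside it, the step of a number 6 percentage points lower from compound 1 to compound 2 (within the scatter) lying within the scatter. Compound 3, `Nc1scc(-c2cccc([N+](=O)[O-])c2)c1C(=O)c1ccc(Cl)cc1`, differs from compound 1 by nitro in place of hydrogen on an aromatic carbon. Among the compounds with values here, the only step that bears on this, a bromo in place of hydrogen on an aromatic carbon, moved the read-out by an amount within the scatter, so no change beyond the scatter is expected here either. Compound 3 is therefore estimated at 47%, between 30% and 64%, an expected step of a number 4 percentage points lower from compound 1 to compound 3 (within the scatter).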

Compound 3, a percentage reported as activity, at one concentration (the size of the read-out at that concentration, not a potency): 53%
For compound 3 the middle estimate is 6 percentage points below the measured one, and the stated range covers the measured number.
By their numbers in this assay, from the lowest: compounds 2, 1 and 3 (each within the scatter of the next).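

In this assay, nitro in place of hydrogen on an aromatic carbon, meta to a large group, gives a number 2 percentage points higher from compound 1 to compound 3 (within the scatter). So the read-out also holds at this place with a group of 3 heavy atoms and 2 hydrogen-bond acceptors, which the bromo step could not show. No evidence on hand accounts for this result. As far as these compounds go, whether an amine, a carboxylic acid or a longer chain at this place would leave the read-out as it is remains open. So does whether nitro would do the same on another carbon of this ring.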